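This account rests on a few compounds, and the source may have more. Where it says the series, first, only, none or still open, it means among the compounds named here.

Measured compounds:
Compound 1, `COc1cc(-c2cc(/C=C/C(=O)c3ccc(Cl)c(Cl)c3)[nH]n2)cc(OC)c1OC`, gives 114% in a functional assay on SK-MEL-28 cells (Homo sapiens) for cytotoxicity, read by sulforhodamine B assay, with a stated time of 48 h, tested at 1 uM; a lower number here means a stronger effect, a higher number a weaker effect of the compound at the concentration tested.
Compound 2, `COc1ccc(C(=O)/C=C/c2cc(-c3cc(OC)c(OC)c(OC)c3)n[nH]2)cc1`, gives 101% in this assay.

Compound 2 stands lowest of the two numbers, and its nearest neighbour is compound 1, which lies higher; the step of a number 13 percentage points lower from compound 1 to compound 2 (beyond the scatter) is beyond the scatter, so these two compounds are told apart, though neither shows a strong effect at the concentration tested.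

Compound 3, `COc1cc(-c2cc(/C=C/C(=O)c3ccc(F)c(F)c3)[nH]n2)cc(OC)c1OC`, has not yet been measured. It differs from compound 2 in one place: 3,4-difluorophenyl in place of 4-methoxyphenyl on a carbonyl carbon. For the measured compounds named here, the only measured step that bears on this change is the one from compound 1 to compound 2, where a 3,4-dichlorophenyl gave way to a 4-methoxyphenyl on the same carbonyl carbon and the number fell by a number 13 percentage points lower from compound 1 to compound 2 (beyond the scatter). Compound 3 returns to a ring bearing two halogens, so a small rise back toward compound 1 is the expectation, though likely within the scatter. For compound 3 the estimate in this assay is 108%, with a range from 92% to 122%, which is expected to mean a step of a number 7 percentage points higher from compound 2 to compound 3 (within the scatter).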

Compound 3, a percentage reported as activity, at one concentration (the size of the read-out at that concentration, not a potency): 98%
Compound 3: middle estimate off by 10 percentage points, on the high side, and the stated range covers the measured number.
By their numbers in this assay, from the lowest: compounds 3 and 2 (each within the scatter of the next); then compound 1.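

In this assay, placing 3,4-difluorophenyl in place of 4-methoxyphenyl on the carbonyl carbon gives a number 3 percentage points lower from compound 2 to compound 3 (within the scatter) and so these two rings cannot be told apart in this read-out. Placing 3,4-difluorophenyl in place of 3,4-dichlorophenyl at the same carbon gives a number 16 percentage points lower from compound 1 to compound 3 (beyond the scatter) and so having two halogens on this ring does not settle the number on its own, since the choice of halogen separates compound 1 from compound 3. Nothing available here explains why the fluorine and chlorine rings differ or why the fluorine and methoxy rings do not.

Going by these compounds, all three compounds carry a substituted phenyl ring on this carbonyl carbon, so it remains open how an unsubstituted phenyl, a ring bearing an amine or a ring bearing a carboxylic acid would behave. Because each compound is read at a single concentration and none shows a strong effect, these numbers also leave open how the compounds would rank at higher concentrations.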